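The source may report more compounds than this note shows. Statements on the series, on what has been measured and on what is new or still open speak of the compounds shown alone.

Compound 1 `COC1Cc2cc(-c3ccccc3)sc2C2(CCN(Cc3ccccc3)CC2)O1` gives 16 nM in an assay on membranes from brain for displacement of a labelled ligand from Sigma non-opioid intracellular receptor 1 (Cavia porcellus), read by scintillation counting, with a stated time of 120 min (on this read-out lower numbers stand for stronger inhibition and higher numbers for weaker inhibition), and compound 2 `COC1Cc2cc(-c3ccc(C#N)cc3)sc2C2(CCN(Cc3ccccc3)CC2)O1` gives 20 nM in this assay. Compound 2 carries the higher of the two numbers, but the step of a 1.3-fold higher number from compound 1 to compound 2 (0.10 log units; within the scatter) lies within the scatter, so no ranking is claimed. Compound 3 `COC1Cc2cc(-c3cccnc3)sc2C2(CCN(Cc3ccccc3)CC2)O1` differs from compound 2 by pyridin-3-yl in place of 4-cyanophenyl on an aromatic carbon. Among the compounds with values here, the only measured step, from compound 1 to compound 2, touched the same aryl group and was within the scatter, so compound 3 is expected to show a 1.3-fold higher number from compound 2 to compound 3 (0.10 log units; within the scatter), nothing beyond the scatter. Compound 3 is therefore estimated at 25 nM, within 8 nM to 80 nM.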

Compound 3, inhibition constant: 2.5 nM
Estimate against measurement, compound 3: 10-fold (1.00 log units) above; measured number below the stated range.
By their numbers in this assay, from the lowest: compound 3; then compounds 1 and 2 (each within the scatter of the next).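

In this assay, the aryl group on the aromatic carbon next to the ring sulfur proves able to move the number: pyridin-3-yl brings an 8.0-fold lower number from compound 2 to compound 3 (0.90 log units; beyond the scatter) and a 6.4-fold lower number from compound 1 to compound 3 (0.81 log units; beyond the scatter). Adding cyano to the phenyl group had shown no such shift, so replacing the carbon-only ring with a ring holding a nitrogen does what that substitution did not. No measured evidence here accounts for this difference. The compounds shown leave open whether pyridin-4-yl or pyridin-2-yl would give a similarly low number, and whether pyrimidin-5-yl would lower it further.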